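Hydrogen in place of cyano on compound 1

The source may report more compounds than this note shows. Statements on the series, on what has been measured and on what is new or still open speak of the compounds shown alone.

Compound 1 `N#Cc1cccc(NC(=O)c2cc(F)ccc2O)c1` gives 9100 nM
Compound 2 `N#Cc1ccc2nc(-c3ccccc3O)[nH]c2c1` gives > 10000 nM

Among the measured compounds shown here, in a functional assay on KG-1 cells (Homo sapiens) for cytotoxicity, read by luminescence and CellTiter-Glo, with a stated time of 3 days (a higher number here means a weaker inhibitor, a lower number a stronger inhibitor), compound 1 holds the only actual number so far, at 9100 nM on the scale. For compound 2 the result is a limit, > 10000 nM and not a number.

For the measured compounds named here, compound 3 `O=C(Nc1ccccc1)c1cc(F)ccc1O` has hydrogen in place of cyano on an aromatic carbon of compound 1, on a six-membered aromatic ring of carbon only, meta to a large group hydrogen in place of cyano on an aromatic carbon and no measured pair shows what this change does. Going by the values given here, with compound 1 at 9100 nM as the only guide, no step beyond the usual scatter is expected in this assay and any drift would more likely be toward weaker inhibition. The estimated 1.2-fold higher number from compound 1 to compound 3 (0.08 log units; within the scatter) stays within that scatter. Compound 3 is expected at 11000 nM with an estimated range from 5000 nM to 25000 nM in this measurement.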

Compound 3, half-maximal inhibitory concentration: > 10000 nM
Compound 3 was reported as a limit; the forecaster's own chance of this, stated with the estimate: 55%; the middle value is on the limit's open side.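

Hydrogen in place of cyano on an aromatic carbon gives the first step that can be read at this position in this assay, and it is only a floor: an at least 1.0-fold higher number from compound 1 to compound 3 (0.04 log units; that floor lies within the scatter). The pair therefore shows that removing the nitrile brings no gain in inhibition, which compound 2, differing from compound 1 in more than one place, could not show. The true size of the step stays unreadable because the values run into the same limit of the measurement: the limit of > 10000 nM in this assay, at which 2 of the 3 values shown sit.

On these data alone, how far compound 3 lies past its limit remains open. So does whether another group at this place, such as an amine or a carboxylic acid, would move the value clearly away from that of compound 1, at 9100 nM.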